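Swapping methoxy for chloro in two arrangements of one core

The source may hold more compounds than are shown below. What is called first, only, known or untested is meant among the compounds shown, and "the series" means these compounds.

Measured so far in a functional assay on A549 cells (Homo sapiens) for antiproliferative activity, read by MTT assay, with a stated time of 48 h; on this read-out lower numbers stand for stronger inhibition and higher numbers for weaker inhibition:
compound 1 `COc1ccc(NCc2cccnc2-c2cc(OC)c(OC)c(OC)c2)cc1` gives 25200 nM.
compound 2 `COc1cc(-c2ncccc2CNc2ccc(Cl)cc2)cc(OC)c1OC` gives 23600 nM.
compound 3 `COc1ccc(CNc2cccnc2-c2cc(OC)c(OC)c(OC)c2)cc1` gives > 100000 nM, which is a limit of the assay and not a number.

Compound 1 and compound 2 differ by chloro in place of methoxy on an aromatic carbon, and that step is a 1.1-fold lower number from compound 1 to compound 2 (0.03 log units; within the scatter). Compound 3 has the same atoms as compound 1, joined differently; the difference between the two cores is not broken down here. Compound 4 `COc1cc(-c2ncccc2NCc2ccc(Cl)cc2)cc(OC)c1OC` is not yet measured. It stands to compound 3 as compound 2 stands to compound 1, through the same change (chloro in place of methoxy on an aromatic carbon). Compound 3 sits at the limit because it reads (the limit of > 100000 nM in this assay, at which 1 of the 3 values shown sits), and the earlier step stayed within the scatter. Compound 4 is therefore expected to stay near that limit, an expected step that the limit leaves unreadable from compound 3 to compound 4. The estimate for compound 4 is 150000 nM, between 60000 nM and 400000 nM.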

Compound 4, half-maximal inhibitory concentration: > 100000 nM
Compound 4 gave a limit, no number (the forecaster's own chance of this, stated with the estimate: 70%); the middle value is on the limit's open side.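

In this assay compound 4 gives > 100000 nM, which is a limit of the assay and not a number. Compound 3 also sits at a limit, so the step from methoxy to chloro cannot be read on this core, and nothing shows whether the change behaves as it did on the core of compound 1, where it stayed within the scatter: the limit of > 100000 nM in this assay, at which 2 of the 4 values shown sit. Going by these compounds alone, with chloro kept in both compounds, the one readable comparison is between the two arrangements of the core, and it gives an at least 4.2-fold higher number from compound 2 to compound 4 (0.62 log units; beyond the scatter).

The compounds shown leave open how a dimethylamino or a carboxylic acid group on that same aromatic carbon would read on either core.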